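Adding a chloro to compound 3

This account rests on a few compounds, and the source may have more. Where it says the series, first, only, none or still open, it means among the compounds named here.

Of the compounds shown here, three of one series have been measured so far in a physicochemical assay for lipophilicity, using the shake flask method, measured as octanol-water partition, at pH 7.4 (a higher number here means a more lipophilic compound, a lower number a more polar compound), for this account. Compound 1 `CC(=O)N[C@@H]1CCC[C@H](C(=O)Nc2cc(-c3cnn(C)c3C)c(Cl)cn2)C1` gives 2.6 and compound 2 `CC(=O)N[C@@H]1CCC[C@H](C(=O)Nc2cc(-c3cnc4ccccn34)c(Cl)cn2)C1` gives 3 in that measurement. Within the data shown here, the only measured step is a number 0.40 log units higher from compound 1 to compound 2 (beyond the scatter) and it exchanges one aromatic group for another while the chloro stays in place. Compound 3 `CC(=O)N[C@@H]1CCC[C@H](C(=O)Nc2cc(-c3cnn4c3CC(C)(C)C4)ccn2)C1` gives 2.8 and lies within the scatter of both of those compounds.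

Compound 4 `CC(=O)N[C@@H]1CCC[C@H](C(=O)Nc2cc(-c3cnn4c3CC(C)(C)C4)c(Cl)cn2)C1` differs from compound 3 at a single place (chloro in place of hydrogen on an aromatic carbon), with chloro in place of hydrogen on an aromatic carbon. Among the measured compounds shown here, compound 1 and compound 2 carry this chloro as well, but no measured pair shows its addition alone, and the one measured step bears on it only loosely. That step, a number 0.40 log units higher from compound 1 to compound 2 (beyond the scatter) gives the only size available, a modest one. A modest upward move in this assay is therefore expected, although the direction has no direct measured support. The expected change is a number 0.50 log units higher from compound 3 to compound 4 (beyond the scatter) on this estimate. Compound 4 is thus estimated at 3.3 with an expected range from 2.9 to 3.7 in this measurement.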

Compound 4, distribution coefficient: 3.8
Beside the measured number, compound 4's estimate is 0.50 log units below it; measured number above the stated range.
By their numbers in this assay, from the lowest: compounds 1, 3 and 2 (each within the scatter of the next, the first and the last beyond it); then compound 4.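

In this assay, among these compounds, the pair compound 3 and compound 4 isolates chloro in place of hydrogen on an aromatic carbon for the first time, and the change alone gives a number 1.00 log units higher from compound 3 to compound 4 (beyond the scatter) at this carbon of the six-membered aromatic ring, ortho to a large group and para to another. With the chloro held constant, exchanging the other aromatic group also shifts the number, giving a number 0.80 log units higher from compound 2 to compound 4 (beyond the scatter) and a number 1.20 log units higher from compound 1 to compound 4 (beyond the scatter), so compound 4 stands highest of the four, beyond the scatter of each of the others. Nothing available explains the size of the chloro step or of these group exchanges.

Going by these compounds, the chloro effect rests on this single pair, so whether it would be of similar size with the groups of compound 1 or compound 2 remains open. It is equally open how this assay would respond to a fluoro, a methoxy or an amine in place of the chloro on this aromatic carbon, since the compounds shown compare the chloro only with hydrogen.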